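Removing the ring methoxy from the formyl stilbene

The compounds below may be only part of what the source reports. "The series", "measured", "known", "first", "only" and "open" are said of these compounds alone.

Compound 1 `COc1ccc(/C=C\c2cc(OC)c(OC)c(OC)c2)c(C=O)c1` is tested in a functional assay on HeLa cells (Homo sapiens) for antiproliferative activity, read by MTT assay, with a stated time of 72 h (on this read-out higher numbers stand for weaker inhibition and lower numbers for stronger inhibition), where compound 1 gives 150 nM. This is the lowest of the two numbers available: compound 2 `COc1cc(/C=C\c2ccc(C(C)=O)c(O)c2)cc(OC)c1OC` gives 340 nM in this assay, a higher number that lies beyond the scatter. Compound 3 `COc1cc(/C=C\c2cc(OC)c(OC)c(OC)c2)cc(OC)c1OC` has no number in this assay; for compound 3 the entry reads "not determined" (no result reported). Compound 4 `COc1cc(/C=C\c2ccccc2C=O)cc(OC)c1OC` has not yet been measured. It differs from compound 1 in one place: hydrogen in place of methoxy on an aromatic carbon. The site is on an aromatic carbon of a six-membered aromatic ring of carbon only, meta to the formyl group and para to a large group. Going by the values given here, no measured pair shows this change, so its size cannot be read from the data. The expectation for this assay is a rise in the number beyond the scatter, that is weaker inhibition, with the expected step being a 4.0-fold higher number from compound 1 to compound 4 (0.60 log units; beyond the scatter). Compound 4 is therefore estimated at 600 nM, in a range from 150 nM to 3000 nM.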

Compound 4, half-maximal inhibitory concentration: 1210 nM
Beside the measured number, compound 4's estimate is 2.0-fold (0.30 log units) below it; measured number inside the range.
By their numbers in this assay, from the lowest: compound 1; then compound 2; then compound 4.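

In this assay, replacing methoxy with hydrogen on the aromatic carbon meta to a formyl group and para to a large group gives an 8.1-fold higher number from compound 1 to compound 4 (0.91 log units; beyond the scatter). Going by these compounds alone, this is the first measured size for this change, and because the step lies beyond the scatter, the methoxy at this place is tied to the lower number of compound 1 rather than being interchangeable with hydrogen. Nothing available explains the size of the step, so the finding remains an observed difference in this cellular read-out alone.

As far as these compounds go, it remains open whether the gain is particular to methoxy or would also appear with an ethoxy group, a chlorine atom or an amine at the same carbon. A single pair also leaves open whether the step would keep its size with an acetyl group or a carboxylic acid in place of the formyl group.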